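From Amides to a Pyridylmethyl Ester at the Carbonyl

The source may hold more compounds than are shown below. What is called first, only, known or untested is meant among the compounds shown, and "the series" means these compounds.

Measured compounds:
compound 1 `CCn1c(C(=O)N(C)c2ccccc2)ccc1C(CC)(CC)c1ccc(OCC(=O)C(C)(C)C)c(C)c1` gives 18500 nM.
compound 2 `CCn1c(C(=O)Nc2ccc(OC(F)(F)F)cc2)ccc1C(CC)(CC)c1ccc(OCC(=O)C(C)(C)C)c(C)c1` gives > 50000 nM, a limit of the assay.
compound 3 `CCOc1ccc(NC(=O)c2ccc(C(CC)(CC)c3ccc(OCC(=O)C(C)(C)C)c(C)c3)n2CC)cc1` gives > 50000 nM, a limit of the assay.

The three measured compounds share one core and differ only in the group attached to a carbonyl carbon. Among the measured compounds shown here, in an assay on HL-60 cells for agonist activity at vitamin D3 receptor (Homo sapiens), read by microscopy, with a stated time of 96 h (on this read-out lower numbers stand for an effect already at smaller amounts and higher numbers for an effect only at larger amounts of compound), compound 1 is the only one with a numbered value. For compound 2 the reading is a limit, not a number. For compound 3 the reading is likewise a limit. Compound 3 therefore stands at the limit of > 50000 nM in this assay, at which 2 of the 3 values shown sit, together with compound 2. The step of an at least 2.7-fold higher number from compound 1 to compound 2 (0.43 log units; beyond the scatter) and the step of an at least 2.7-fold higher number from compound 1 to compound 3 (0.43 log units; beyond the scatter) both run upward, while the step that the two limits leave unreadable from compound 2 to compound 3 is not readable.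

Compound 4 `CCn1c(C(=O)OCc2ccccn2)ccc1C(CC)(CC)c1ccc(OCC(=O)C(C)(C)C)c(C)c1` has not been measured. It differs from compound 3 by (pyridin-2-yl)methoxy in place of (4-ethoxyphenyl)amino on a carbonyl carbon. For the measured compounds named here, no measured step covers this kind of change: all three measured compounds carry a nitrogen on that carbonyl carbon, whereas compound 4 carries an oxygen there. Going by the values given here, the measured steps show only that two of three groups on this carbon already reach the limit and that the one numbered value is high. On that basis a step of about an at least 1.6-fold lower number from compound 3 to compound 4 (0.22 log units; that floor lies within the scatter) is expected for compound 4 in this assay, with a sizeable chance that only a limit is returned again. The estimate for compound 4 is 30000 nM, within a range from 8000 nM to 100000 nM.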

Compound 4, half-maximal effective concentration: > 50000 nM
Compound 4: only a limit was reported; the forecaster's own chance of this, stated with the estimate: 50%; middle value at least 1.6-fold (0.22 log units) from the limit.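

In this assay compound 4 gives > 50000 nM, which is a limit of the assay and not a number. This is the first compound shown with an oxygen rather than a nitrogen on the carbonyl carbon, and that (pyridin-2-yl)methoxy group does not return a numbered value, leaving one readable step: an at least 2.7-fold higher number from compound 1 to compound 4 (0.43 log units; beyond the scatter). Among the four groups shown on this carbon, only the methyl(phenyl)amino group of compound 1 gives a number, so an oxygen link and a ring with a hetero atom join the two substituted anilino groups at the same limit: the limit of > 50000 nM in this assay, at which 3 of the 4 values shown sit.

As far as these compounds go, the steps linking compound 4 with compound 2 and compound 3 cannot be read, as both ends of each are limits, so the order of these three groups and the separate contributions of the oxygen and the pyridine ring stay unknown. Also open, from the compounds shown here alone, is what smaller groups on the same carbonyl carbon would give, such as the methoxy of a simple methyl ester, the hydroxyl of a carboxylic acid or a dimethylamino group.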